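Swapping phenoxymethyl for cyclohexyl on a shared core

The source may report more compounds than this note shows. Statements on the series, on what has been measured and on what is new or still open speak of the compounds shown alone.

compound 1 `O=C(COc1ccccc1)Nc1nnc(-c2cccc(O)c2O)s1` gives 11200 nM
compound 2 `O=C(COc1ccccc1)Nc1nnc(-c2ccc(O)c(O)c2)s1` gives 17400 nM
compound 3 `O=C(Nc1nnc(-c2ccc(O)c(O)c2)s1)c1ccc(Cl)cc1` gives 14700 nM

These three numbers come from a functional assay on HL-60 cells (Homo sapiens) for cytotoxicity, read by MTT assay, with a stated time of 72 h (a lower number here means a stronger inhibitor, a higher number a weaker inhibitor), and lie within the scatter of one another, so compound 1 stands level with the other two rather than ahead of them.

Compound 4 `O=C(Nc1nnc(-c2cccc(O)c2O)s1)C1CCCCC1` is still unmeasured and differs from compound 1 in a single place (cyclohexyl in place of phenoxymethyl on a carbonyl carbon): cyclohexyl in place of phenoxymethyl on a carbonyl carbon.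

The closest evidence is another swap on a carbonyl carbon, 4-chlorophenyl in place of phenoxymethyl, which gave a 1.2-fold lower number from compound 2 to compound 3 (0.07 log units; within the scatter) and so did not move the number beyond the scatter. The other measured step, 3,4-dihydroxyphenyl in place of 2,3-dihydroxyphenyl, gave a 1.6-fold higher number from compound 1 to compound 2 (0.19 log units; within the scatter) and also stayed within the scatter, but it concerns a different part of the structure and bears on this change only indirectly. Going by the values given here, no measured compound carries cyclohexyl, so the evidence is thin.

In this assay no step beyond the scatter is expected, in either direction. The estimated change is a 1.2-fold higher number from compound 1 to compound 4 (0.06 log units; within the scatter) and would be no real shift. Compound 4 is expected at 13000 nM with an estimated range from 6500 nM to 28000 nM as the likely span.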

Compound 4, half-maximal inhibitory concentration: 7900 nM
Compound 4: middle estimate off by 1.6-fold (0.22 log units), on the high side; the measured number falls inside the stated range.
By their numbers in this assay, from the lowest: compounds 4, 1, 3 and 2 (each within the scatter of the next, the first and the last beyond it).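

In this assay, putting cyclohexyl in place of phenoxymethyl on the carbonyl carbon gave a 1.4-fold lower number from compound 1 to compound 4 (0.15 log units; within the scatter), so this swap did not move the number beyond the scatter. The earlier compounds shown here carried only groups with an aromatic ring at this place, whereas cyclohexyl has a non-aromatic ring and lacks the hydrogen-bond acceptor counted in phenoxymethyl. This single comparison therefore shows that, on the core of compound 1, neither the aromatic ring nor that acceptor needs to be present for the number to stay within the scatter. Nothing measured here explains why the number held, so the step stands as an observation only.

The compounds shown leave open whether a much smaller group such as methyl, a longer chain such as n-octyl, or a group carrying an amine or a carboxylic acid at this place would shift the number beyond the scatter. They also leave open whether cyclohexyl would behave in the same way with 3,4-dihydroxyphenyl in place of 2,3-dihydroxyphenyl on the other side of the core.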